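This account rests on a few compounds, and the source may have more. Where it says the series, first, only, none or still open, it means among the compounds named here.

Compound 1 `COc1ccc(-c2cc3c(OC)ccc(OC)c3nc2O)cc1`: 10000 nM
Compound 2 `CCOC(=O)Cn1c(=O)c(-c2ccc(OC)cc2)cc2c(OC)cc(OC)cc21`: 10000 nM

In a functional assay on A549 cells (Homo sapiens) for cytotoxicity, read by colorimetric assay and MTT assay (a higher number here means a weaker inhibitor, a lower number a stronger inhibitor), compound 1 gives 10000 nM and compound 2 gives 10000 nM, so the two stand level, within the usual scatter. Compound 3 `COc1ccc(-c2cc3c(OC)cc(OC)cc3n(CC(=O)OCc3ccccc3)c2=O)cc1` changes one place of compound 2: phenyl in place of methyl on a saturated chain carbon bound to an oxygen next to a carbonyl group. This is phenyl in place of methyl on a saturated chain carbon bound to an oxygen next to a carbonyl group, turning ethoxycarbonyl into benzyloxycarbonyl. Among the measured compounds shown here, no measured pair yet shows what this change does, so only a cautious expectation is possible. The expected step of a 1.3-fold lower number from compound 2 to compound 3 (0.10 log units; within the scatter) is small, with nothing beyond the scatter. Compound 3 is estimated at 8000 nM, with an expected range from 3000 nM to 12000 nM.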

Compound 3, half-maximal inhibitory concentration: 10000 nM
Compound 3: middle estimate off by 1.3-fold (0.10 log units), on the low side, and the stated range covers the measured number.
By their numbers in this assay, from the lowest: compounds 1, 2 and 3 (each within the scatter of the next).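

Putting phenyl in place of methyl on a saturated chain carbon bound to an oxygen next to a carbonyl group gives no change at the digits printed from compound 2 to compound 3 (within the scatter) in this assay. At this position, then, ethoxycarbonyl and benzyloxycarbonyl read alike, and the added six-membered aromatic ring leaves no mark on the number. No available evidence offers an explanation for this result.

As far as these compounds go, whether a carboxylic acid or an amide at this position would read differently stays open. So does the effect of a longer chain carrying the phenyl.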